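This account rests on a few compounds, and the source may have more. Where it says the series, first, only, none or still open, it means among the compounds named here.

Compound 3 `O=C(Nc1ccnnc1)c1cc(N2CCCCC2)ccc1OCc1ccccc1` gives 6.3 in a physicochemical assay for lipophilicity, at pH 7.4 (a higher number here means a more lipophilic compound, a lower number a more polar compound), the highest of the three numbers seen so far; its nearest neighbour is compound 2 `CN1CC2(CCN(c3ccc(OCc4ccccc4)c(C(=O)Nc4ccnnc4)c3)CC2)C1`, which gives 2.2, and the furthest is compound 1 `O=C(Nc1ccnnc1)c1cc(N2CCNCC2)ccc1OCc1ccccc1`, which gives 1.9. Compound 4 `C[C@@H]1CN(c2ccc(OCc3ccccc3)c(C(=O)Nc3ccnnc3)c2)C[C@H](C)O1` is not yet measured. It differs from compound 3 in one place: 2,6-dimethylmorpholin-4-yl in place of piperidin-1-yl on an aromatic carbon.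

Among the measured compounds shown here, two measured steps bear on this change, since both also swap the ring on that aromatic carbon: a number 4.40 log units higher from compound 1 to compound 3 (beyond the scatter) and a number 4.10 log units higher from compound 2 to compound 3 (beyond the scatter). In both, a six-membered ring with two hetero atoms gave way to piperidin-1-yl, and the number climbed by a large amount. Compound 4 goes the other way, back to a ring with two hetero atoms, though here the second one is an oxygen rather than a nitrogen, a case the measured compounds do not cover. The step expected for compound 4 is therefore a number 1.20 log units lower from compound 3 to compound 4 (beyond the scatter), a drop beyond the scatter that is smaller than those two measured steps. For compound 4 the estimate is 5.1, with a range from 3.9 to 6.3.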

Compound 4, distribution coefficient: 5.4
Estimate against measurement, compound 4: 0.30 log units below; the measured number falls inside the stated range.
By their numbers in this assay, from the lowest: compounds 1 and 2 (each within the scatter of the next); then compound 4; then compound 3.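

In this assay, 2,6-dimethylmorpholin-4-yl in place of piperidin-1-yl gives a number 0.90 log units lower from compound 3 to compound 4 (beyond the scatter), while the other two new steps are far larger, at a number 3.20 log units higher from compound 2 to compound 4 (beyond the scatter) and a number 3.50 log units higher from compound 1 to compound 4 (beyond the scatter). At this position, then, a second hetero atom in the six-membered ring does not by itself bring the number down to those of compound 1 and compound 2: with oxygen as that atom and two methyl groups on the ring, compound 4 stands much closer to compound 3. Nothing shown here accounts for the size of these steps.

The oxygen and the two methyl groups enter together in compound 4, so their shares of the step cannot be separated. An unsubstituted morpholin-4-yl group at this position would address that, and a 4-methylpiperazin-1-yl group would extend the comparison with compound 1.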